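A Methoxy Group Added to a Shared Anticonvulsant Core

This account rests on a few compounds, and the source may have more. Where it says the series, first, only, none or still open, it means among the compounds named here.

Of the compounds shown here, two built on one shared core have been tested in a functional assay on the whole organism (strain Swiss albino) with Mus musculus as the target, in the maximal electroshock model, with a stated time of 4 h; on this read-out higher numbers stand for an effect only at larger amounts of compound and lower numbers for an effect already at smaller amounts. Compound 1 `O=C(N/N=C\c1ccccc1)Nc1nnc(COc2ccc3ccccc3c2)o1` carries a single aromatic ring at the end of its hydrazone arm, and in this assay compound 1 gives 300 mg/kg. Compound 2 `O=C(NN=C(c1ccccc1)c1ccccc1)Nc1nnc(COc2ccc3ccccc3c2)o1` carries two such rings at that position; in this assay compound 2 gives 300 mg/kg, which at the digits shown is level with compound 1 and lies within the usual scatter of repeated measurements. For the measured compounds named here, no steps between measured pairs have been worked out here, so the two values can only be read as standing together.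

Compound 3 `COc1ccc(/C(=N\NC(=O)Nc2nnc(COc3ccc4ccccc4c3)o2)c2ccccc2)cc1` has not yet been measured. It differs from compound 2 by methoxy in place of hydrogen on an aromatic carbon. Given that compound 1 at 300 mg/kg and compound 2 at 300 mg/kg stand level, the step from compound 2 to compound 3 is expected to stay within the scatter, with no direction beyond it: no change at the digits printed from compound 2 to compound 3 (within the scatter). Compound 3 is expected to give about 300 mg/kg in this assay, with a plausible range from 100 mg/kg to 600 mg/kg.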

Compound 3, minimum effective dose: 300 mg/kg
Beside the measured number, compound 3's estimate shows no gap at the digits printed, and the stated range covers the measured number.
By their numbers in this assay, from the lowest: compounds 1, 2 and 3 (each within the scatter of the next).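

In this assay, putting methoxy in place of hydrogen on an aromatic carbon, para to a large group, gives no change at the digits printed from compound 2 to compound 3 (within the scatter) and so adds a first piece of information about substitution on one of the two rings at the end of the hydrazone arm. The earlier compounds shown here spoke only to whether one or two such rings stood there, whereas this step shows that a group of 2 heavy atoms, with 1 hydrogen-bond acceptor and no net charge, can sit on that ring with no difference readable on this measure. No measurement of any property bears on why the value holds steady here.

One methoxy group in one place cannot show how far this tolerance extends, since a small group is only a single test of the position. From the compounds shown here alone, whether an amine, a carboxylic acid or a longer chain such as butoxy in the same place would keep the effect at the same dose or shift it in either direction remains open.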